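Proline amide cap variation in the sulfonamide series

The compounds below may be only part of what the source reports. "The series", "measured", "known", "first", "only" and "open" are said of these compounds alone.

Of the compounds shown here, three have been measured in a functional assay on U2OS cells for antagonist activity at proto-oncogene Wnt-3 (Homo sapiens), read by a luciferase reporter, with a stated time of 18 h; on this read-out lower numbers stand for an effect already at smaller amounts and higher numbers for an effect only at larger amounts of compound. Compound 1 `O=C1CC[C@@H](C(=O)N2CCC(NS(=O)(=O)c3cc(S(=O)(=O)c4ccccc4)ccc3C(F)(F)F)CC2)N1` gives 240 nM. Compound 2 `CC(=O)N1CCC[C@H]1C(=O)N1CCC(NS(=O)(=O)c2cc(S(=O)(=O)c3ccccc3)ccc2C(F)(F)F)CC1` gives 250 nM. Compound 3 `CN(C)c1ccc(C(=O)N2CCC[C@H]2C(=O)N2CCC(NS(=O)(=O)c3cc(S(=O)(=O)c4ccccc4)ccc3C(F)(F)F)CC2)cc1` gives 830 nM, the highest of the three numbers; the nearest other number belongs to compound 2 and the furthest to compound 1, both beyond the scatter.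

The cap on the carbonyl carbon at the pyrrolidine nitrogen is the varied position. The step of a 1.0-fold higher number from compound 1 to compound 2 (0.02 log units; within the scatter) shows no difference between the two small caps. The step of a 3.3-fold higher number from compound 2 to compound 3 (0.52 log units; beyond the scatter) shows that the larger aryl cap raises the number, a modest shift.

Compound 4 `CC(C)(C)NC(=O)N1CCC[C@H]1C(=O)N1CCC(NS(=O)(=O)c2cc(S(=O)(=O)c3ccccc3)ccc2C(F)(F)F)CC1` carries the change ((tert-butyl)amino in place of 4-(dimethylamino)phenyl on a carbonyl carbon). Among the measured compounds shown here, the cap of compound 4 is small, as in compound 2, and the only step that bears on the change is the one from the small acetyl cap to the aryl cap, now run in reverse direction. Compound 4 is therefore expected to move back down toward the number of compound 2, a step of a 2.4-fold lower number from compound 3 to compound 4 (0.38 log units; beyond the scatter). The estimate for compound 4 in this assay is 350 nM, with a range from 150 nM to 900 nM.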

Compound 4, half-maximal effective concentration: 30 nM
Beside the measured number, compound 4's estimate is 12-fold (1.07 log units) above it; the measured number lies below the stated range.
By their numbers in this assay, from the lowest: compound 4; then compounds 1 and 2 (each within the scatter of the next); then compound 3.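

In this assay the (tert-butyl)amino cap does more than restore the level of the small caps: the change from the aryl cap gives a 28-fold lower number from compound 3 to compound 4 (1.44 log units; beyond the scatter) and the comparisons with the small caps give an 8.3-fold lower number from compound 2 to compound 4 (0.92 log units; beyond the scatter) and an 8.0-fold lower number from compound 1 to compound 4 (0.90 log units; beyond the scatter) at this position. Compounds 1 and 2 had suggested a flat level for small caps with a rise for the aryl cap, whereas compound 4 shows that the number can go well below that level, so cap size alone does not order the four compounds. The change removes the aromatic ring of carbon and brings in one hydrogen-bond donor on the carbonyl carbon, but no measurement in hand explains the drop.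

The compounds shown do not separate the part played by the tert-butyl group from that of the amide-type hydrogen on the amino nitrogen; a dimethylamino cap, or a tert-butyl group set directly on the carbonyl carbon, would bear on this. Going by these compounds, it also stays open how a smaller amine such as methylamino or a cyclohexylamino cap would compare with compound 4.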